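Replacing a sulfonyl-bearing ring on the shared core

This account rests on a few compounds, and the source may have more. Where it says the series, first, only, none or still open, it means among the compounds named here.

Of the compounds shown here, three share one core and have been tested in a functional assay on HCC827 cells (Homo sapiens) for antiproliferative activity, read by MTT assay, with a stated time of 72 h; on this read-out higher numbers stand for weaker inhibition and lower numbers for stronger inhibition. Compound 1 `CN1CCN(c2ccc(Nc3ncc4nc(Nc5ccccc5)n([C@H]5CCN(S(C)(=O)=O)C5)c4n3)cc2)CC1` gives 17 nM. Compound 2 `CN1CCN(c2ccc(Nc3ncc4nc(Nc5ccc(F)cc5)n([C@H]5CCCN(S(=O)(=O)C6CC6)C5)c4n3)cc2)CC1` gives 8.6 nM, the lowest of the three numbers; its nearest neighbour is compound 1, and its furthest is compound 3 `CC(=O)N1CC[C@H](n2c(Nc3ccccc3)nc3cnc(Nc4ccc(N5CCN(C)CC5)cc4)nc32)C1`, which gives 260 nM.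

Compound 4 `CNC(=O)CN1CC[C@H](n2c(Nc3ccc(F)cc3)nc3cnc(Nc4ccc(N5CCN(C)CC5)cc4)nc32)C1` has not yet been measured. It differs from compound 2 in one place: 1-((methylcarbamoyl)methyl)pyrrolidin-3-yl in place of 1-(cyclopropylsulfonyl)piperidin-3-yl on an aromatic nitrogen.

Among the measured compounds shown here, one measured step bears on this change. Going from compound 1 to compound 3 swaps an acetyl for a methylsulfonyl on an amine nitrogen in a ring, and this gave a 15-fold higher number from compound 1 to compound 3 (1.18 log units; beyond the scatter). In compound 4 the sulfonyl group also leaves, and the ring that carried it is replaced by a smaller one bearing a (methylcarbamoyl)methyl chain. For the measured compounds named here, no measured pair isolates the ring-size change or the chain alone, so the loss of the sulfonyl is the only guide.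

On that basis compound 4 is expected to give a higher number in this assay than compound 2, a step estimated as a 7.0-fold higher number from compound 2 to compound 4 (0.84 log units; beyond the scatter). The estimate for compound 4 is therefore 60 nM, expected to fall between 15 nM and 250 nM.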

Compound 4, half-maximal inhibitory concentration: 1520 nM
Estimate against measurement, compound 4: 25-fold (1.40 log units) below, and the stated range ends below it.
By their numbers in this assay, from the lowest: compounds 2 and 1 (each within the scatter of the next); then compound 3; then compound 4.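

In this assay the change on the aromatic nitrogen gives a 180-fold higher number from compound 2 to compound 4 (2.25 log units; beyond the scatter) and this step is larger than the earlier 15-fold higher number from compound 1 to compound 3 (1.18 log units; beyond the scatter) in which only the group on the ring nitrogen was exchanged. This shows that the group on this aromatic nitrogen can move the number very far, and that replacing the whole substituent can cost more than exchanging the sulfonyl group alone. Both steps remove a sulfonyl group and both raise the number, and no compound here goes against that, although the entering chain also brings a hydrogen-bond donor that the leaving group lacks and nothing measured here explains the size of the rise.

Among the compounds shown here, how the step divides among the loss of the cyclopropylsulfonyl group, the change from a six-membered to a five-membered ring and the arrival of the (methylcarbamoyl)methyl chain stays open, as no pair here changes only one of these. Also open, as far as these compounds go, is how a carboxylic acid or a primary amine at the end of that chain, or a longer chain, would read on the same ring nitrogen.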